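The source may report more compounds than this note shows. Statements on the series, on what has been measured and on what is new or still open speak of the compounds shown alone.

In an ADME assay on microsomes from liver (Homo sapiens) for metabolic stability (a higher number here means faster removal of the compound, a lower number slower removal), compound 1 `COc1ccc([C@H](C)NC(=O)Cn2nnc3ccccc3c2=O)cc1` gives 13 mL/min/kg, and compound 3 `Cc1ccc([C@@H](NC(=O)Cn2nnc3ccccc3c2=O)C(C)C)cc1` gives 34 mL/min/kg. Compound 2 `C[C@H](NC(=O)Cn1nnc2ccccc2c1=O)c1ccc(Br)cc1` reads < 9.9 mL/min/kg, which is a limit of the assay and not a number. Its standing is therefore known only through (the limit of < 9.9 mL/min/kg in this assay, at which 1 of the 3 values shown sits).

Compound 4 `C[C@H](NC(=O)Cn1nnc2ccccc2c1=O)c1nccs1` is not yet measured. The change is 1,3-thiazol-2-yl in place of 4-bromophenyl on a saturated chain carbon bound to an amide-type nitrogen and a saturated chain carbon.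

Going by the values given here, the only measured step, an at least 1.3-fold lower number from compound 1 to compound 2 (0.11 log units; that floor lies within the scatter), is bromo in place of methoxy on an aromatic carbon. That is a different change, its floor lies within the scatter, and it gives no size for replacing the whole ring. No step beyond the scatter is therefore expected in this assay, and no direction can be assigned with confidence. The expected step is an at least 1.2-fold higher number from compound 2 to compound 4 (0.08 log units; that floor lies within the scatter). For compound 4 the estimate is 12 mL/min/kg, with an expected range from 8 mL/min/kg to 24 mL/min/kg.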

Compound 4, clearance: < 9.9 mL/min/kg
Compound 4: a limit, no number; the forecaster's own chance of this, stated with the estimate: 40%; middle value at least 1.2-fold (0.08 log units) from the limit.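

In this assay, compound 4 reads < 9.9 mL/min/kg, which is a limit of the assay and not a number. The earlier compounds shown here showed only bromo in place of methoxy on an aromatic carbon; this result shows that the whole 4-bromophenyl on the saturated chain carbon bound to an amide-type nitrogen and a saturated chain carbon can give way to 1,3-thiazol-2-yl with the reading still at the assay limit. Set against 4-methoxyphenyl at this place, 1,3-thiazol-2-yl gives an at least 1.3-fold lower number from compound 1 to compound 4 (0.11 log units; that floor lies within the scatter).

On these data alone, the step between compound 2 and compound 4 cannot be read, so their order stays open: the limit of < 9.9 mL/min/kg in this assay, at which 2 of the 4 values shown sit. Also open is whether an amine or a carboxylic acid in place of the ring at this position would leave the reading at the limit.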